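Nitrofuran carboxamide sulfonamides: piperidine 4-substituent series

The source may hold more compounds than are shown below. What is called first, only, known or untested is meant among the compounds shown, and "the series" means these compounds.

Measured compounds:
compound 1 `O=C(Nc1ccc(S(=O)(=O)N2CCC(Cl)CC2)cc1)c1ccc([N+](=O)[O-])o1` — 4800 nM
compound 2 `CC1CCN(S(=O)(=O)c2ccc(NC(=O)c3ccc([N+](=O)[O-])o3)cc2)CC1` — 4600 nM

Compound 2 gives 4600 nM in a functional assay on MEF cells (Mus musculus) for antiproliferative activity, read by luminescence, with a stated time of 16 h; a higher number here means that more compound is needed for the effect, a lower number that less compound is needed. It holds the lowest of the two numbers, with compound 1 nearest; the step of a 1.0-fold lower number from compound 1 to compound 2 (0.02 log units; within the scatter) lies within the scatter, so the two compounds are not distinguishable here.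

Compound 3 `CC1(C)CCN(S(=O)(=O)c2ccc(NC(=O)c3ccc([N+](=O)[O-])o3)cc2)CC1` is not yet measured. It differs from compound 2 by methyl in place of hydrogen on a saturated ring carbon. Within the data shown here, the only measured step, from chloro to methyl at this same ring carbon, left the number unchanged within the scatter, and no step adding a further methyl at this position has been measured, so there is no direct precedent for the change.

Given that the one nearby exchange produced no movement beyond the scatter, compound 3 is expected to give about 4500 nM, in a range from 2000 nM to 10000 nM. The step of a 1.0-fold lower number from compound 2 to compound 3 (0.01 log units; within the scatter) is thus estimated to stay within the scatter, with no clear direction.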

Compound 3, half-maximal effective concentration: 3000 nM
For compound 3 the middle estimate is 1.5-fold (0.18 log units) above the measured one; low and high end bracket the measured number.
By their numbers in this assay, from the lowest: compounds 3, 2 and 1 (each within the scatter of the next).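

In this assay, a second methyl on this saturated ring carbon, the change from 4-methylpiperidin-1-yl to 4,4-dimethylpiperidin-1-yl, is accommodated without a readable shift: the step (a 1.5-fold lower number from compound 2 to compound 3 (0.19 log units; within the scatter)) stays within the scatter. The wider exchange of 4-chloropiperidin-1-yl for 4,4-dimethylpiperidin-1-yl (a 1.6-fold lower number from compound 1 to compound 3 (0.20 log units; within the scatter)) also stays within the scatter, so chloro, one methyl and two methyls at this carbon cannot be told apart by their numbers. No supporting data are available to account for this flat response.

On these data alone, whether a different kind of group at this ring carbon, such as an amine, a carboxylic acid or a longer chain, would move the number beyond the scatter remains open. Also open, as far as these compounds go, is whether a hydroxyl group here would leave the number as unaffected as the methyl groups did.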